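A few compounds are considered here, and "the series" means these few. Any claim that something is new, unique, unknown or untested is made for them only; others in the source may bear on it.

Working notes on the series. Compound 1 `CCCCCCCCCCn1cc(-c2nc3ccccc3cc2C)nn1` and compound 2 `CCCCCCCCCCn1cc(-c2nc3ccccc3cc2CCCC)nn1` share one core; compound 3 `CCCCCc1cc2ccccc2nc1-c1cn(CCC(F)(F)C(F)(F)C(F)(F)C(F)(F)C(F)(F)C(F)(F)C(F)(F)C(F)(F)F)nn1` and the not yet measured compound 4 `CCc1cc2ccccc2nc1-c1cn(CCC(F)(F)C(F)(F)C(F)(F)C(F)(F)C(F)(F)C(F)(F)C(F)(F)C(F)(F)F)nn1` share another, and the difference between the two cores is not broken down here. The read-out throughout is a functional assay on COLO 205 cells (Homo sapiens) for cytotoxicity, read by MTT assay, with a stated time of 24 h; on this read-out lower numbers stand for stronger inhibition and higher numbers for weaker inhibition.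

In this assay compound 1 gives 44.5 ug/mL. Compound 2 reaches only a limit of the assay in this assay, > 100 ug/mL. The step of an at least 2.2-fold lower number from compound 2 to compound 1 (0.35 log units; beyond the scatter) belongs to the change (hydrogen in place of propyl on a saturated chain carbon bound to an aromatic carbon). Compound 3 also sits at a limit of the assay in this assay, > 100 ug/mL. Two of the three values thus rest on (the limit of > 100 ug/mL in this assay, at which 2 of the 3 values shown sit), which leaves the true spread of the series open.

Compound 4 differs from compound 3 by hydrogen in place of propyl on a saturated chain carbon, two bonds along the chain from an aromatic carbon. This is the same kind of change as the measured one, not the same: there the propyl left a saturated chain carbon bound to an aromatic carbon, here it leaves a saturated chain carbon two bonds along the chain from an aromatic carbon.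

For compound 4 in this assay a step of an at least 1.6-fold lower number from compound 3 to compound 4 (0.22 log units; that floor lies within the scatter) is expected, set beside the measured at least 2.2-fold lower number from compound 2 to compound 1 (0.35 log units; beyond the scatter). From the compounds shown here alone, because compound 3 gives only > 100 ug/mL, the starting point is unknown and a step of similar direction cannot be placed with confidence. Compound 4 is estimated at 60 ug/mL in this assay, expected between 20 ug/mL and 150 ug/mL, with a real chance that only a limit is returned again.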

Compound 4, half-maximal inhibitory concentration: 95.2 ug/mL
Estimate against measurement, compound 4: 1.6-fold (0.20 log units) below, and the stated range covers the measured number.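

In this assay the new step, an at least 1.0-fold lower number from compound 3 to compound 4 (0.02 log units; that floor lies within the scatter), gives only a floor within the scatter, so it neither confirms nor rules out that the change from propyl to hydrogen carries over from the core of compound 1 to the core of compound 4. Among these compounds, compound 3 is at a limit of the assay, > 100 ug/mL, and no size for the step on this core can be read from it. Set beside the step on the other core, the reading is: the same change on two cores in this assay, an at least 2.2-fold lower number (0.35 log units; beyond the scatter) from compound 2 to compound 1 and an at least 1.0-fold lower number (0.02 log units; that floor lies within the scatter) from compound 3 to compound 4; the limit leaves it open whether they differ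

Still open are the true size of the step on either core and the part played by the difference between the two cores, with the spread of the series resting in good part on a single limit: the limit of > 100 ug/mL in this assay, at which 2 of the 4 values shown sit.
Also open is how the series would respond to a group other than those shown at this place on the saturated chain, such as an amine, a carboxylic acid or a longer chain.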